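Chloro for Methyl on a Shared Sulfonamide Core

This account rests on a few compounds, and the source may have more. Where it says the series, first, only, none or still open, it means among the compounds named here.

Four compounds share one core and differ only in the group on the outer aromatic ring. Compound 1 `O=C1Cc2cc(S(=O)(=O)N3CCN(c4ccc(O)cc4)CC3)ccc2N1` carries a hydroxy group there; compound 2 `Cc1ccc(N2CCN(S(=O)(=O)c3ccc4c(c3)CC(=O)N4)CC2)cc1` a methyl group; compound 3 `O=C1Cc2cc(S(=O)(=O)N3CCN(c4ccc(F)cc4)CC3)ccc2N1` a fluoro group; compound 4 `O=C1Cc2cc(S(=O)(=O)N3CCN(c4ccc(Cl)cc4)CC3)ccc2N1` a chloro group. In an assay on isolated protein for inhibition of lysosomal alpha-glucosidase (Homo sapiens), read by fluorescence, with stated times of 5 min and 45 min (a higher number here means a weaker inhibitor, a lower number a stronger inhibitor), compound 1 gives 2370 nM. In this assay compound 2 is reported as "not active" (no number reported), without a single number, and compound 3 is likewise reported as "not active" (no number reported). So compound 2 stands among the entries without a number, while only compound 1 has a measured value.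

The change from compound 2 to compound 4 is chloro in place of methyl on an aromatic carbon. Going by the values given here, no measured step exists for this change, and compound 3 shows that another small group in the same place also gave no number. No clear shift in this assay is expected in either direction; the most likely outcome is again weak or absent inhibition. Compound 4 is therefore estimated at 20000 nM, with a range from 5000 nM to 100000 nM.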

Compound 4, half-maximal inhibitory concentration: 94300 nM
Beside the measured number, compound 4's estimate is 4.7-fold (0.67 log units) below it; measured number inside the range.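

In this assay this place on the outer ring now has two measured numbers, and they give a real step of a 40-fold higher number from compound 1 to compound 4 (1.60 log units; beyond the scatter); chloro in place of hydroxy therefore leaves a much weaker inhibitor. Compound 2 and compound 3 have no single number, and their steps to compound 4 cannot be read, so the change from methyl to chloro has no measured size. Nothing measured here gives a reason for the large step from hydroxy to chloro.

The compounds shown leave open whether hydroxy itself matters or whether another group in the same place, such as an amine or a methoxy group, would give a similar number. They also leave open whether a carboxylic acid there would give stronger or weaker inhibition than hydroxy.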